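The source may report more compounds than this note shows. Statements on the series, on what has been measured and on what is new or still open speak of the compounds shown alone.

Compound 1 `Cc1ccc(C(=O)Nc2cc(Cl)ccc2OCC(=O)Nc2ccc(S(N)(=O)=O)cc2C)c(C)c1` was tested in a functional assay on C8166 cells (Homo sapiens) for cytotoxicity, read by MTT assay (on this read-out lower numbers stand for higher toxicity in this test and higher numbers for lower toxicity in this test), where compound 1 gives 47600 nM. Its companion compound 2 `Cc1ccc(C)c(C(=O)Nc2cc(Cl)ccc2OCC(=O)Nc2ccc(S(N)(=O)=O)cc2C)c1` gives 79700 nM in this assay, and the step of a 1.7-fold higher number from compound 1 to compound 2 (0.22 log units; within the scatter) places the two values within the scatter of each other. Compound 3 `Cc1cc(S(N)(=O)=O)ccc1NC(=O)COc1ccc(Cl)cc1NC(=O)c1ccc2ccccc2c1` differs from compound 1 by naphthalen-2-yl in place of 2,4-dimethylphenyl on a carbonyl carbon. Within the data shown here, no measured step covers such an exchange; the only measured step, a 1.7-fold higher number from compound 1 to compound 2 (0.22 log units; within the scatter), rearranges methyl groups and stays within the scatter, so no step beyond the scatter is expected in this assay. Compound 3 is estimated at 50000 nM, between 20000 nM and 125000 nM, a step of a 1.1-fold higher number from compound 1 to compound 3 (0.02 log units; within the scatter) that is expected.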

Compound 3, half-maximal cytotoxic concentration: 37600 nM
For compound 3 the middle estimate is 1.3-fold (0.12 log units) above the measured one; the measured number falls inside the stated range.
By their numbers in this assay, from the lowest: compounds 3, 1 and 2 (each within the scatter of the next, the first and the last beyond it).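

In this assay, replacing the single ring of 2,4-dimethylphenyl on the carbonyl carbon with the two rings of naphthalen-2-yl gives a 1.3-fold lower number from compound 1 to compound 3 (0.10 log units; within the scatter), so enlarging the aromatic group here causes no clear change. Against the 2,5-dimethylphenyl group, the same kind of exchange gives a 2.1-fold lower number from compound 2 to compound 3 (0.33 log units; beyond the scatter), the only step so far to pass the scatter, and only modestly. Nothing available explains either step.

The compounds shown leave open how the number responds at this position to a group that is not a carbon-only aromatic, such as a pyridine ring, an amine or a carboxylic acid.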